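Bromo for trifluoromethyl in a pyridine-ethyl thiocarbamate series

The source may hold more compounds than are shown below. What is called first, only, known or untested is meant among the compounds shown, and "the series" means these compounds.

Compound 1, `Cc1cccc(NC(=S)OCCc2ccccn2)c1`: > 100000 nM
Compound 2, `O=[N+]([O-])c1cccc(NC(=S)OCCc2ccccn2)c1`: 100000 nM
Compound 3, `FC(F)(F)c1ccc(NC(=S)OCCc2ccccn2)cc1`: 50000 nM

Of the compounds shown here, three sharing one core have been tested in an ADME assay on MT4 cells (Homo sapiens) for cytotoxicity, read by MTT assay; on this read-out higher numbers stand for lower toxicity in this test and lower numbers for higher toxicity in this test. For compound 1 the value of > 100000 nM is a limit of the assay, not a number. In this assay compound 2 gives 100000 nM and compound 3 gives 50000 nM; these two numbers lie within the usual scatter of each other, so neither can be ranked against the other. Among the compounds with values here, the only measured step, a number no higher from compound 1 to compound 2 (the limit leaves the size open), cannot be sized because of the limit of > 100000 nM in this assay, at which 1 of the 3 values shown sits, and it replaces a different group at a different position.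

Compound 4, `S=C(Nc1ccc(Br)cc1)OCCc1ccccn1`, differs from compound 3 by bromo in place of trifluoromethyl on an aromatic carbon. Within the data shown here, no measured step matches this change, and the one step known shows no movement that can be read. Compound 4 is therefore expected to give about 70000 nM, with a range from 25000 nM to 200000 nM. The expected step of a 1.4-fold higher number from compound 3 to compound 4 (0.15 log units; within the scatter) stays within the scatter, with a fair chance that only a limit is reported.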

Compound 4, half-maximal cytotoxic concentration: 37000 nM
The estimate for compound 4 lay 1.9-fold (0.28 log units) above the measured number; the measured number falls inside the stated range.
By their numbers in this assay, from the lowest: compounds 4, 3 and 2 (each within the scatter of the next, the first and the last beyond it).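

In this assay, bromo in place of trifluoromethyl on an aromatic carbon, para to a large group, gives a 1.4-fold lower number from compound 3 to compound 4 (0.13 log units; within the scatter). This is the only readable step among the compounds shown, and it is the first to show this position directly: a group of 4 heavy atoms gives way to one of 1 heavy atom with no movement beyond the scatter. It shows this for this single pair only, and no wider pattern follows from it.

On these data alone, the step from compound 1 to compound 2 cannot be read: the limit of > 100000 nM in this assay, at which 1 of the 4 values shown sits. Still open is whether an amine, a carboxylic acid or a longer chain at this same position would move the number beyond the scatter.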